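The source may report more compounds than this note shows. Statements on the series, on what has been measured and on what is new or still open speak of the compounds shown alone.

Measured compounds:
compound 1 `Cc1cccc(C2(CNC(=O)Nc3c(C(C)C)cccc3C(C)C)CCCC2)c1` — 15 nM
compound 2 `CC(C)c1cccc(C(C)C)c1NC(=O)NCC1(c2ccc(C(C)(C)C)cc2)CCCC1` — 63 nM
compound 3 `COc1cccc(C2(CNC(=O)Nc3c(C(C)C)cccc3C(C)C)CCCC2)c1` — 13 nM

In an assay on microsomes for inhibition of acyl-CoA:cholesterol acyltransferase (Oryctolagus cuniculus) (a higher number here means a weaker inhibitor, a lower number a stronger inhibitor), compound 1 gives 15 nM, the second highest of the three numbers; compound 3 is within the scatter of it, while compound 2 sits well apart. The only variation across the series is the aryl group on a saturated ring carbon, and compound 4 `CC(C)c1cccc(C(C)C)c1NC(=O)NCC1(c2ccc(N)cc2)CCCC1` continues it: 4-aminophenyl in place of 3-methylphenyl on a saturated ring carbon.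

Among the compounds with values here, two measured steps bear on the change. Replacing 3-methylphenyl by 4-(tert-butyl)phenyl gave a 4.2-fold higher number from compound 1 to compound 2 (0.62 log units; beyond the scatter), and going from that group back to 3-methoxyphenyl gave a 4.8-fold lower number from compound 2 to compound 3 (0.69 log units; beyond the scatter); the methyl-to-methoxy swap on the aromatic carbon, a 1.2-fold lower number from compound 1 to compound 3 (0.06 log units; within the scatter), stayed within the scatter. A group carrying a hydrogen-bond donor and acceptor on the ring has not been tested. By analogy with the weakening seen in the step to compound 2, a modest rise in the number is expected for compound 4, a 3.3-fold higher number from compound 1 to compound 4 (0.52 log units; beyond the scatter), with a wide margin on both sides.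

Compound 4 is estimated at 50 nM in this assay, with a range from 15 nM to 200 nM.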

Compound 4, half-maximal inhibitory concentration: 29 nM
For compound 4 the middle estimate is 1.7-fold (0.24 log units) above the measured one; the range from low to high includes it.
By their numbers in this assay, from the lowest: compounds 3, 1 and 4 (each within the scatter of the next, the first and the last beyond it); then compound 2.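

In this assay, 4-aminophenyl, with a hydrogen-bond donor and acceptor that 3-methylphenyl does not have, is accepted on the saturated ring carbon: the swap gives a 1.9-fold higher number from compound 1 to compound 4 (0.29 log units; within the scatter) and stays within the scatter. The same group reads differently against the other two aryl groups, with 3-methoxyphenyl replaced to give a 2.2-fold higher number from compound 3 to compound 4 (0.35 log units; beyond the scatter) and tert-butyl replaced by amino on the aromatic carbon to give a 2.2-fold lower number from compound 2 to compound 4 (0.34 log units; beyond the scatter), so an aryl group with a donor and acceptor on it does not fall as far as compound 2. Nothing available accounts for the size of these steps.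

Open, going by these compounds, is whether a hydroxy, a carboxylic acid or a dimethylamino group in place of the amino would stay close to compound 4. Also open, on these data alone, is whether a smaller alkyl such as ethyl in place of tert-butyl would leave compound 2 apart.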